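The source may report more compounds than this note shows. Statements on the series, on what has been measured and on what is new or still open speak of the compounds shown alone.

In a functional assay on HepG2 cells (Homo sapiens) for inhibition, read by MTT assay, with a stated time of 24 h (a lower number here means a stronger inhibitor, a higher number a weaker inhibitor), compound 1 `CC1(C)[C@H]2CC[C@]1(C)N(Cc1cn(-c3ccccc3O)nn1)C(=O)C2` gives 120 nM and compound 2 `Cc1ccccc1-n1cc(CN2C(=O)C[C@@H]3CC[C@@]2(C)C3(C)C)nn1` gives 150 nM. Going by the values given here, with only these two numbers available, compound 2 stands level with compound 1, since the one measured step is a 1.3-fold higher number from compound 1 to compound 2 (0.10 log units; within the scatter). Compound 3 `CC1(C)[C@H]2CC[C@]1(C)N(Cc1cn(-c3ccc(Cl)cc3)nn1)C(=O)C2` keeps the shared core and differs from compound 2 in a single place: 4-chlorophenyl in place of 2-methylphenyl on an aromatic nitrogen. In words, 4-chlorophenyl stands in place of 2-methylphenyl on an aromatic nitrogen of the five-membered aromatic ring with 3 nitrogen.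

Among the compounds with values here, only that one measured step bears on this change, and it bears only loosely. Within the data shown here, it exchanged hydroxy for methyl on an aromatic carbon, and no measured compound carries a 4-chlorophenyl group. The data therefore give no sign of a shift in either direction, but they also leave the effect of this group untested. No step beyond the scatter is expected in this assay, and the range is kept wide. The expected change is a 1.1-fold lower number from compound 2 to compound 3 (0.03 log units; within the scatter). For compound 3 the estimated value is 140 nM, with an expected range from 50 nM to 400 nM.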

Compound 3, half-maximal inhibitory concentration: 90 nM
For compound 3 the middle estimate is 1.6-fold (0.19 log units) above the measured one; measured number inside the range.
By their numbers in this assay, from the lowest: compounds 3, 1 and 2 (each within the scatter of the next).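

In this assay, 4-chlorophenyl on the aromatic nitrogen gives a 1.7-fold lower number from compound 2 to compound 3 (0.22 log units; within the scatter) and, set against the hydroxy-bearing ring, a 1.3-fold lower number from compound 1 to compound 3 (0.12 log units; within the scatter), so neither exchange moves the number beyond the scatter. The earlier pair showed only that hydroxy and methyl on the same phenyl ring could be exchanged without a step beyond the scatter, while these two steps extend that to a ring carrying a chlorine and bearing its group at a different ring carbon. Among these three compounds, then, 2-hydroxyphenyl, 2-methylphenyl and 4-chlorophenyl on this aromatic nitrogen stand level, though this says nothing about aryl groups beyond the three, and nothing shown here offers an explanation for the numbers.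

Each of these steps alters the group on the phenyl ring and, for 4-chlorophenyl, its place on the ring at the same time, so 2-chlorophenyl or 4-methylphenyl would be needed to tell the two changes apart. Going by these compounds, it also remains open whether a phenyl ring bearing an amine or a carboxylic acid, or a longer alkyl chain in place of the phenyl ring, would give a step beyond the scatter at this position.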